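This account rests on a few compounds, and the source may have more. Where it says the series, first, only, none or still open, it means among the compounds named here.

Measured compounds in an assay on isolated protein (Mus musculus) for inhibition of IL15-IL15 receptor (Homo sapiens), read by resazurin assay, with stated times of 30 min and 2.5 days; on this read-out lower numbers stand for stronger inhibition and higher numbers for weaker inhibition:
compound 1, `Cn1c(Cc2nn(C)c(=O)c3ccccc23)nnc1SCCCCCCCC(=O)Nc1ccc(Br)cc1Br`: 1500 nM
compound 2, `CC(C)COc1ccc(NC(=O)CSc2nnc(Cc3nn(C)c(=O)c4ccccc34)n2C)cc1`: 30000 nM
compound 3, `CC(C)Oc1ccc(NC(=O)CSc2nnc(Cc3nn(C)c(=O)c4ccccc34)n2C)cc1`: a limit of the assay, > 30000 nM

Compound 1 stands lowest of the two numbers available; the nearest, compound 2, sits well beyond the scatter from it, and the only other value is the limit shown for compound 3. Among the measured compounds shown here, the one step measured within the set is a number no lower from compound 2 to compound 3 (the limit leaves the size open), which runs against the limit of > 30000 nM in this assay, at which 1 of the 3 values shown sits, and so cannot be sized.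

Compound 4, `CC(C)Oc1ccc(NC(=O)CCCCCCCSc2nnc(Cc3nn(C)c(=O)c4ccccc34)n2C)cc1`, is not yet measured. It differs from compound 1 as 4-isopropoxyphenyl in place of 2,4-dibromophenyl on an amide-type nitrogen; the chain on the sulfur and the amide are kept as in compound 1. For the measured compounds named here, no measured step bears on this change directly: the step from compound 2 to compound 3 varies only the alkoxy group, and the bromophenyl appears only in compound 1. What the data do show is that the alkoxyphenyl amide with the short chain, compound 2, gives 30000 nM, well beyond the scatter from compound 1. Compound 3, the other alkoxyphenyl amide with the short chain, sits at a limit of the assay. On that basis a step of a 5.3-fold higher number from compound 1 to compound 4 (0.73 log units; beyond the scatter) toward a higher number is expected, and for compound 4 a value of about 8000 nM is estimated, expected to fall between 2000 nM and 30000 nM.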

Compound 4, half-maximal inhibitory concentration: 1100 nM
Estimate against measurement, compound 4: 7.3-fold (0.86 log units) above, outside the stated range (below it).
By their numbers in this assay, from the lowest: compounds 4 and 1 (each within the scatter of the next); then compound 2.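

In this assay, 4-isopropoxyphenyl in place of 2,4-dibromophenyl on the amide-type nitrogen gives a 1.4-fold lower number from compound 1 to compound 4 (0.13 log units; within the scatter). With the long chain on the sulfur kept, this position therefore accepts an alkoxyphenyl as well as a dibromophenyl, and the bromines are not required for a value in this range. Compound 3, which carries the same 4-isopropoxyphenyl with the short chain on the sulfur, has a limit and not a number: the limit of > 30000 nM in this assay, at which 1 of the 4 values shown sits.

The compounds shown leave open how the value moves with chain lengths between the short chain and the long one, and whether a still longer chain goes further. Also open, from the compounds shown here alone, is how this position responds to an amine or a carboxylic acid on the phenyl ring in place of the alkoxy group.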